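The source may hold more compounds than are shown below. What is called first, only, known or untested is meant among the compounds shown, and "the series" means these compounds.

Measured compounds in a functional assay on MDA-MB-231 cells (Homo sapiens) for cytotoxicity, read by MTT assay, with a stated time of 48 h, in the presence of a further agent that is not named here; a higher number here means a weaker inhibitor, a lower number a stronger inhibitor:
compound 1, `COc1ccc(NC(=O)c2csc(-c3cn(Cc4ccc(Cl)cc4)c4ccccc34)n2)cc1`, > 100000 nM
compound 2, `COc1ccc2[nH]cc(-c3nc(C(=O)Nc4cc(OC)c(OC)c(OC)c4)cs3)c2c1`, > 100000 nM

Both numbers shown for this assay are limits, not measured values. In this assay compound 1 reaches only the limit > 100000 nM. In this assay compound 2 likewise reaches only the limit > 100000 nM. Compound 2 therefore stands at the ceiling of what was measured, together with the other value, as summarised by the limit of > 100000 nM in this assay, at which 2 of the 2 values shown sit; no ordering between the two is possible. Among the compounds with values here, no step between measured compounds is available, so nothing on the series shows the effect of a single change.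

Compound 3 `COc1cc(NC(=O)c2csc(-c3c[nH]c4ccc(Br)cc34)n2)cc(OC)c1OC` differs from compound 2 by bromo in place of methoxy on an aromatic carbon. With both values already at the limit, the expected step is none beyond the scatter, in no particular direction, and compound 3 is expected to remain at or near the limit. Compound 3 is estimated at 150000 nM in this assay, with a range from 30000 nM to 1000000 nM. The implied change a step that the limit leaves unreadable from compound 2 to compound 3 is an expectation, not a measurement.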

Compound 3, half-maximal inhibitory concentration: > 100000 nM
Compound 3: no number, only a limit (the forecaster's own chance of this, stated with the estimate: 75%); the middle value is on the limit's open side.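

In this assay compound 3 reaches only the limit > 100000 nM. Compound 2 also stands at a limit, so the step between compound 2 and compound 3 cannot be read. The compounds shown leave open what any single change does to potency, with every value at one ceiling: the limit of > 100000 nM in this assay, at which 3 of the 3 values shown sit.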